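This account rests on a few compounds, and the source may have more. Where it says the series, first, only, none or still open, it means among the compounds named here.

Measured so far:
- compound 1 `O=C(CCCCCCc1ccccc1)c1ncno1`, in an assay for inhibition of Fatty-acid amide hydrolase 1 (Rattus norvegicus) (on this read-out higher numbers stand for weaker inhibition and lower numbers for stronger inhibition), compound 1 gives 4 nM
- compound 2 `O=C(CCCCCCc1ccccc1)c1nncs1`, in this assay compound 2 gives 300 nM

Among the measured compounds shown here, compound 2 holds the highest of the two numbers, and its only neighbour is compound 1, reached by a 75-fold higher number from compound 1 to compound 2 (1.88 log units; beyond the scatter). Compound 3 `O=C(CCCCCCc1ccccc1)c1nnn[nH]1` differs from compound 2 by 1H-tetrazol-5-yl in place of 1,3,4-thiadiazol-2-yl on a carbonyl carbon. For the measured compounds named here, the single measured step, from compound 1 to compound 2, shows that exchanging the five-membered ring on the carbonyl carbon can shift this assay by a large margin, so a further sizeable change is expected here, most likely towards a higher number. Compound 3 is therefore estimated at 1500 nM, within 200 nM to 10000 nM, which would mean an expected step of a 5.0-fold higher number from compound 2 to compound 3 (0.70 log units; beyond the scatter).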

Compound 3, half-maximal inhibitory concentration: 600 nM
Estimate against measurement, compound 3: 2.5-fold (0.40 log units) above; the measured number falls inside the stated range.
By their numbers in this assay, from the lowest: compound 1; then compounds 2 and 3 (each within the scatter of the next).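

Putting 1H-tetrazol-5-yl in place of 1,3,4-thiadiazol-2-yl on a carbonyl carbon gives a 2.0-fold higher number from compound 2 to compound 3 (0.30 log units; within the scatter), so this assay does not separate these two rings, even though only the 1H-tetrazol-5-yl group carries a hydrogen-bond donor. A second replacement of the 1,2,4-oxadiazol-5-yl group also gives a large step, a 150-fold higher number from compound 1 to compound 3 (2.18 log units; beyond the scatter), which sets compound 1 apart from both other compounds. No evidence is available to explain these results.

The compounds shown leave open how an oxazol-2-yl or pyridin-2-yl ring on the carbonyl carbon would read, and whether the large gap persists with a shorter chain.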